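Arylsulfonamide thiazoles: alkyne substituent change on compound 2

The compounds below may be only part of what the source reports. "The series", "measured", "known", "first", "only" and "open" are said of these compounds alone.

Measured so far:
- compound 1 `CC(=O)Nc1nc(-c2cccc(NS(=O)(=O)c3cccc(Br)c3)c2)cs1`: "not active" (no number reported)
- compound 2 `CC(=O)Nc1nc(-c2cccc(NS(=O)(=O)c3cccc(C#CCO)c3)c2)cs1`: 85.4%

Going by the values given here, in a functional assay on A-375 cells (Homo sapiens) for antiproliferative activity, read by trypan blue exclusion, with a stated time of 48 h, tested at 1 uM (a lower number here means a stronger effect, a higher number a weaker effect of the compound at the concentration tested), compound 2 gives 85.4%, the only number in the set. Among the compounds with values here, compound 1 is recorded in this assay as "not active" (no number reported) without a figure, so no step between the two can be sized; the two entries show only that compound 2 has a measured value and compound 1 does not.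

Compound 3 `CC(=O)Nc1nc(-c2cccc(NS(=O)(=O)c3cccc(C#C[Si](C)(C)C)c3)c2)cs1` is not yet measured. It differs from compound 2 by a group of 4 heavy atoms (3 carbon, 1 silicon; no ring) in place of a group of 2 heavy atoms (1 carbon, 1 oxygen; no ring), on a triple-bonded carbon. Within the data shown here, no measured pair isolates such an exchange, so no observed step supports a direction. The expectation is therefore a step in this assay from compound 2 that stays within the usual scatter, or at most slightly downward.

For compound 3 the estimated value in this assay is 80%, with a range from 55% to 100%. The expected step is a number 5.4 percentage points lower from compound 2 to compound 3 (within the scatter).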

Compound 3, a percentage reported as activity, at one concentration (the size of the read-out at that concentration, not a potency): 61.6%
Beside the measured number, compound 3's estimate is 18.4 percentage points above it; measured number inside the range.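

In this assay, going by these compounds alone, replacing hydroxymethyl on the triple-bonded carbon with the group of 4 heavy atoms (3 carbon, 1 silicon) gives a number 23.8 percentage points lower from compound 2 to compound 3 (beyond the scatter), the first step that can be sized. The read-out therefore responds to what sits on this triple-bonded carbon, and the direction here is towards a stronger effect at the concentration tested; steps involving compound 1 cannot be read, as it has no number. Nothing available bears on the origin of this step.

This single exchange changes the heavy-atom count, the atom types and the hydrogen-bond donor and acceptor counts together, so these cannot be separated. A tert-butyl group or an aminomethyl group on the same triple-bonded carbon would be needed to tell them apart.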